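Dropping the acetoxy end: compound 3 to compound 4

This account rests on a few compounds, and the source may have more. Where it says the series, first, only, none or still open, it means among the compounds named here.

Of the compounds shown here, three have been measured in a physicochemical assay for lipophilicity; a higher number here means a more lipophilic compound, a lower number a more polar compound. Compound 1 `CCCCOC(=O)/C=C(C)/C=C/CC(C)CCCC(C)(C)OC` gives 6.62. Compound 2 `CCOC(=O)/C=C(C)/C=C/CC(C)CCCC(C)(C)OC(C)=O` gives 5.57. Compound 3 `CC(=O)OC(C)(C)CCCC(C)C/C=C/C(C)=C/C(=O)OC(C)C` gives 5.98, the second highest of the three, with compound 2 nearest below it and compound 1 furthest above it. Within the data shown here, the one step measured between neighbours, a number 0.41 log units higher from compound 2 to compound 3 (beyond the scatter), concerns the alkyl end of the chain and is modest.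

Compound 4 `CC(C)=CCCC(C)C/C=C/C(C)=C/C(=O)OC(C)C` has not yet been measured. It differs from compound 3 in one place: 2-methylprop-1-en-1-yl in place of 2-acetoxy-2-methylpropyl on a saturated chain carbon, four bonds along the chain from a double-bonded chain carbon. Among the measured compounds shown here, this change lies at the other end of the molecule from the measured step, so no measured step bears on it directly, and compound 1 differs from compound 3 in more than one place, so its value only shows that this series can reach higher numbers. With two hydrogen-bond acceptors leaving and only carbon entering, an upward step is expected for compound 4, a number 0.82 log units higher from compound 3 to compound 4 (beyond the scatter), beyond the scatter. The expected value for compound 4 in this assay is 6.8, estimated to lie between 6.2 and 7.4.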

Compound 4, partition coefficient: 6.6
Beside the measured number, compound 4's estimate is 0.20 log units above it, and the stated range covers the measured number.
By their numbers in this assay, from the lowest: compound 2; then compound 3; then compounds 4 and 1 (each within the scatter of the next).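

Replacing 2-acetoxy-2-methylpropyl with 2-methylprop-1-en-1-yl on a saturated chain carbon, four bonds along the chain from a double-bonded chain carbon, gives in this assay a number 0.62 log units higher from compound 3 to compound 4 (beyond the scatter) and shows that this end of the molecule, not only the alkyl end of the ester, can shift the number beyond the scatter. The change is a bundled one: the group that leaves has 8 heavy atoms, including 2 oxygen atoms, and 2 hydrogen-bond acceptors, while the group that enters has 4 heavy atoms, all carbon, and no hydrogen-bond acceptors, so this single step cannot be divided among those differences. Nothing available explains the size of the step.

Going by these compounds, it remains open how much of the step belongs to the acetoxy group alone. A hydroxyl group or a saturated isobutyl end in this place could help separate the contributions.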